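Amide variation on the trimethoxyphenyl benzylamide series

The compounds below may be only part of what the source reports. "The series", "measured", "known", "first", "only" and "open" are said of these compounds alone.

Measured so far:
compound 1 `C/C=C/C(=O)N(Cc1cccc(O)c1)c1cc(OC)c(OC)c(OC)c1` gives 14100 nM in a functional assay on MGC-803 cells (Homo sapiens) for inhibition, read by MTT assay, with a stated time of 48 h; on this read-out higher numbers stand for weaker inhibition and lower numbers for stronger inhibition;
compound 2 `C/C=C/C=C/C(=O)N(Cc1ccc(OC)c(O)c1)c1cc(OC)c(OC)c(OC)c1` gives 140 nM in this assay;
compound 3 `C#CC(=O)N(Cc1ccc(OC)c(O)c1)c1cc(OC)c(OC)c(OC)c1` gives 170 nM in this assay.

Compound 3 stands second of the three numbers, with compound 2 within the scatter of it and compound 1 far weaker. Among the compounds with values here, the only single-point step known, a 1.2-fold higher number from compound 2 to compound 3 (0.08 log units; within the scatter), is within the scatter. Compound 4 `COc1ccc(CN(C(=O)C=C(C)C)c2cc(OC)c(OC)c(OC)c2)cc1O` carries 2-methylprop-1-en-1-yl in place of ethynyl on a carbonyl carbon. Within the data shown here, no measured step isolates this change; compound 1, the other alkene-bearing amide, also differs in its benzyl ring, so its weak value cannot be attributed to the alkene alone. A step weaker than compound 3 is nevertheless expected, an 8.8-fold higher number from compound 3 to compound 4 (0.95 log units; beyond the scatter), with wide uncertainty. Compound 4 is estimated at 1500 nM, range 300 nM to 8000 nM.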

Compound 4, half-maximal inhibitory concentration: 320 nM
Estimate against measurement, compound 4: 4.7-fold (0.67 log units) above, and the stated range covers the measured number.
By their numbers in this assay, from the lowest: compounds 2, 3 and 4 (each within the scatter of the next, the first and the last beyond it); then compound 1.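

In this assay the step of a 1.9-fold higher number from compound 3 to compound 4 (0.27 log units; within the scatter) stays within the scatter, so on a carbonyl carbon whose other neighbour is the amide-type nitrogen, 2-methylprop-1-en-1-yl and ethynyl are not separated. Within the data shown here, the step of a 2.3-fold higher number from compound 2 to compound 4 (0.36 log units; beyond the scatter) is modest, but it is the first change at this place to pass beyond the scatter. No evidence on hand accounts for either step. Still open, on these data alone, is whether a saturated chain such as butyl, or an amine such as dimethylaminomethyl, would hold up on this carbonyl carbon.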